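Replacing a Butylpiperazine Tail with a Hydroxypiperidine

The source may report more compounds than this note shows. Statements on the series, on what has been measured and on what is new or still open speak of the compounds shown alone.

The series shares one core, carried by compound 1 `CCCCN1CCN(CCCCn2c3c(c4ccccc42)C(=O)c2c[n+]([O-])c4ccccc4c2C3=O)CC1`, compound 2 `O=C1c2c[n+]([O-])c3ccccc3c2C(=O)c2c1c1ccccc1n2Cc1cn([C@H]2C[C@H](O)[C@@H](CO)O2)nn1` and compound 3 `O=C1c2c[n+]([O-])c3ccccc3c2C(=O)c2c1c1ccccc1n2Cc1cn([C@@H]2O[C@H](CO)[C@@H](O)[C@H](O)[C@H]2O)nn1`. In a toxicity assay on L02 cells (Homo sapiens) for cytotoxicity, read by MTT assay, with a stated time of 72 h (on this read-out lower numbers stand for stronger inhibition and higher numbers for weaker inhibition), compound 1 gives 5690 nM, the highest number of the three. Within the data shown here, compound 2 gives 280 nM and compound 3 gives 420 nM; the one measured step, a 1.5-fold higher number from compound 2 to compound 3 (0.18 log units; within the scatter), concerns the sugar on the triazole and lies within the scatter.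

Compound 4 `O=C1c2c[n+]([O-])c3ccccc3c2C(=O)c2c1c1ccccc1n2CCCN1CCC(O)CC1` is not yet measured. It differs from compound 1 in the chain on the aromatic nitrogen: 4-hydroxypiperidin-1-yl in place of (4-butylpiperazin-1-yl)methyl on a saturated chain carbon, three bonds along the chain from an aromatic nitrogen. Among the measured compounds shown here, no measured pair changes this chain, so the step from compound 2 to compound 3 bears only indirectly on it, showing that a swap at the far end of the side chain left the number where it was. Because compound 1 stands at 5690 nM, well above the two sugar compounds, a shorter chain with a hydroxyl is expected to bring at most a modest change, estimated as a 1.6-fold lower number from compound 1 to compound 4 (0.21 log units; within the scatter). Compound 4 is therefore estimated at 3500 nM in this assay, with a range from 1200 nM to 10000 nM.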

Compound 4, half-maximal inhibitory concentration: 120 nM
Beside the measured number, compound 4's estimate is 29-fold (1.46 log units) above it; measured number outside the range, below it.
By their numbers in this assay, from the lowest: compound 4; then compounds 2 and 3 (each within the scatter of the next); then compound 1.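

In this assay, the chain on the aromatic nitrogen proves to be a place where the number can move far: a 47-fold lower number from compound 1 to compound 4 (1.68 log units; beyond the scatter), whereas the sugar swap on the triazole gave only a 1.5-fold higher number from compound 2 to compound 3 (0.18 log units; within the scatter). A change at the far end of a side chain therefore does not always leave the number where it was, and here 4-hydroxypiperidin-1-yl in place of (4-butylpiperazin-1-yl)methyl makes a large difference. Nothing at hand accounts for the size of this step.

This single step changes the butyl group, the second ring nitrogen and the hydroxyl together, so the compounds shown cannot say which of these goes with the lower number. A plain piperidin-1-yl group or a 4-(2-hydroxyethyl)piperazin-1-yl group at this place would help to separate them.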